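A second methoxy group at the assay limit

A few compounds are considered here, and "the series" means these few. Any claim that something is new, unique, unknown or untested is made for them only; others in the source may bear on it.

In an ADME assay on BJ cells (Homo sapiens) for cytotoxicity, read by MTT assay, with a stated time of 72 h (on this read-out higher numbers stand for weaker inhibition and lower numbers for stronger inhibition), compound 3 (`COc1cccc(CNc2ncnc3c2ncn3C2CCCO2)c1`) gives > 100000 nM as a limit, not a number. Compound 1 (`Oc1ccccc1CNc1ncnc2c1ncn2C1CCCO1`) gives > 100000 nM as a limit too. Compound 2 (`Oc1cccc(CNc2ncnc3c2ncn3C2CCCO2)c1`) likewise gives > 100000 nM as a limit. The series thus shows only the limit of > 100000 nM in this assay, at which 3 of the 3 values shown sit, and nothing finer. Compound 4 (`COc1ccc(CNc2ncnc3c2ncn3C2CCCO2)cc1OC`) differs from compound 3 by one change: methoxy in place of hydrogen on an aromatic carbon with methoxy in place of hydrogen on an aromatic carbon. The closest measured change is a step that the two limits leave unreadable from compound 2 to compound 3 and the others are a step that the two limits leave unreadable from compound 1 to compound 2 and a step that the two limits leave unreadable from compound 1 to compound 3 so none offers a size. No step beyond the scatter is expected, and the estimated step is a number no higher from compound 3 to compound 4 (the limit leaves the size open) in this assay for this change. Compound 4 is estimated at 100000 nM with an expected range from 50000 nM to 200000 nM in all likelihood reported as a limit.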

Compound 4, half-maximal inhibitory concentration: > 100000 nM
Compound 4 was reported as a limit (the forecaster's own chance of this, stated with the estimate: 85%); the middle value lies on the limit itself.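

Going by these compounds alone, compound 3 and compound 4 both stand at a limit, so no step between them can be read in this assay. The compounds shown leave open how far any of them lies past the limit: the limit of > 100000 nM in this assay, at which 4 of the 4 values shown sit.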